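A few compounds are considered here, and "the series" means these few. Any claim that something is new, unique, unknown or untested is made for them only; others in the source may bear on it.

Compound 2, `FC(F)(F)c1ccc(Nc2ncnc3sc(Nc4c(Cl)cccc4Cl)nc23)cc1`, is the strongest of the two compounds for which a functional assay on HEK293 cells for antagonist activity at transient receptor potential cation channel subfamily V member 1 (Rattus norvegicus), read by calcium flux (on this read-out lower numbers stand for stronger inhibition and higher numbers for weaker inhibition), returned a number: its 3 nM sits well clear of compound 1, `FC(F)(F)c1ccc(Nc2ncnc3c2CCN(c2ncccc2C(F)(F)F)C3)cc1`, which gives 71 nM in this assay. Compound 3, `FC(F)(F)c1ccc(Nc2cccc3sc(Nc4c(Cl)cccc4Cl)nc23)cc1`, is the third member of the set, and in this assay compound 3 reached only a limit, > 5000 nM, not a number. Compound 4, `CN(c1nc2c(Nc3ccc(C(F)(F)F)cc3)ncnc2s1)c1c(Cl)cccc1Cl`, differs from compound 2 in one place: methyl in place of hydrogen on a nitrogen on an aromatic ring, so that the (2,6-dichlorophenyl)amino group of compound 2 becomes a (2,6-dichlorophenyl)(methyl)amino group. Among the measured compounds shown here, no measured pair in this set shows this change, so the direction must be judged without a precedent. The expectation is that the step from compound 2 to compound 4, a 10-fold higher number from compound 2 to compound 4 (1.00 log units; beyond the scatter), goes toward weaker inhibition and is larger than the scatter. Compound 4 is therefore estimated at 30 nM in this assay, with a range from 5 nM to 300 nM.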

Compound 4, half-maximal inhibitory concentration: 540 nM
Compound 4: middle estimate off by 18-fold (1.26 log units), on the low side; the measured number lies above the stated range.
By their numbers in this assay, from the lowest: compound 2; then compound 1; then compound 4. At a limit, above all of these: compound 3.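

In this assay, the change from a (2,6-dichlorophenyl)amino group to a (2,6-dichlorophenyl)(methyl)amino group gives a 180-fold higher number from compound 2 to compound 4 (2.26 log units; beyond the scatter), a large move toward weaker inhibition. Among the compounds shown here, this is the first pair in the set that differs in one place, and it shows that a single added carbon on this nitrogen is enough to cost most of the strength of compound 2, though compound 4 still returns a number. Compound 3 alone stands at a limit, which is not a number: the limit of > 5000 nM in this assay, at which 1 of the 4 values shown sits.

The compounds shown leave open whether the loss follows the missing hydrogen or the added methyl. They also leave open how an ethyl group, an acetyl group or a longer chain on this same nitrogen would read.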